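The source may report more compounds than this note shows. Statements on the series, on what has been measured and on what is new or still open speak of the compounds shown alone.

Working notes on the nitroimidazole-derived series in an ADME assay on MRC5 cells (Homo sapiens) for cytotoxicity, read by resazurin assay, with a stated time of 72 h; a lower number here means a stronger inhibitor, a higher number a weaker inhibitor.

Compound 1 has the structure `CC1(COc2ccc(Cl)cc2)CCn2cc([N+](=O)[O-])nc2O1`. In this assay compound 1 gives >= 40000 nM, which is a limit of the assay and not a number. Compound 2, `CC1(COc2ccc(F)cc2)CCn2cc([N+](=O)[O-])nc2O1`, carries the change fluoro in place of chloro on an aromatic carbon relative to compound 1. In this assay compound 2 gives >= 40000 nM, again a limit rather than a number. The step that the two limits leave unreadable from compound 1 to compound 2 therefore cannot be sized from these two results.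

Compound 3 has the structure `CN(CC1(C)CCn2cc([N+](=O)[O-])nc2O1)c1ccc(Cl)cc1`. How the core of compound 3 differs from the core of compound 1 is not broken down here. In this assay compound 3 gives >= 40000 nM, which is a limit of the assay and not a number.

Compound 4, not yet measured, has the structure `CN(CC1(C)CCn2cc([N+](=O)[O-])nc2O1)c1ccc(F)cc1` and differs from compound 3 by fluoro in place of chloro on an aromatic carbon. The place described for this change matches the place described for the change from compound 1 to compound 2 word for word, so it is the same change made on a different core.

Every result so far sits at the limit of >= 40000 nM in this assay, at which 3 of the 3 values shown sit. Among the measured compounds shown here, the only measured example of this change, the step from compound 1 to compound 2, leaves both partners at the limit. No size can be read for it. For compound 4 the expected step is a number no higher from compound 3 to compound 4 (the limit leaves the size open), resting on compound 3 sitting at >= 40000 nM and on the unreadable step from compound 1 to compound 2. Compound 4 is estimated at 40000 nM, with a range from 20000 nM to 120000 nM, and most likely the assay will again report only a limit.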

Compound 4, half-maximal inhibitory concentration: >= 40000 nM
Compound 4 ended at the assay's limit (the forecaster's own chance of this, stated with the estimate: 85%); the middle value sits exactly at the limit.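

No step can be read from compound 3 to compound 4, nor from compound 1 to compound 2, because each of these results is a limit of the assay and not a number: the limit of >= 40000 nM in this assay, at which 4 of the 4 values shown sit. The compounds shown leave open whether any of them would give a readable value in this assay, and whether the change from 4-chlorophenyl to 4-fluorophenyl moves that value on either core.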